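Replacing the hydroxy group with nitro in a hydroxy amide series

The source may report more compounds than this note shows. Statements on the series, on what has been measured and on what is new or still open speak of the compounds shown alone.

Measured in a functional assay on HuTu80 cells (Homo sapiens) for antiproliferative activity, read by MTT assay, with a stated time of 72 h; a lower number here means a stronger inhibitor, a higher number a weaker inhibitor:
- compound 1 `COc1ccc([C@@H]2[C@H](O)C(=O)N2c2cc(OC)c(OC)c(OC)c2)cc1N`: 101 nM
- compound 2 `COc1ccc([C@@H]2[C@H](O)C(=O)N2c2cc(OC)c(OC)c(OC)c2)cc1O`: 28.8 nM

Going by the values given here, of these two, compound 2 holds the lower number, at 28.8 nM in this assay, and compound 1 is its only neighbour. The next change leads to compound 3 `COc1ccc([C@@H]2[C@H](O)C(=O)N2c2cc(OC)c(OC)c(OC)c2)cc1[N+](=O)[O-]`, which keeps the core of compound 2 and differs at one place: nitro in place of hydroxy on an aromatic carbon. The nitro group takes the place of hydroxy on an aromatic carbon, ortho to a methoxy group.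

Among the compounds with values here, only one measured step bears on this carbon: a 3.5-fold lower number from compound 1 to compound 2 (0.54 log units; beyond the scatter). It is modest but beyond the scatter, and it shows that the hydroxy compound holds the lower number of the pair. Within the data shown here, no nitro compound has been measured yet, so this single step gives direction only loosely. A move away from hydroxy is therefore expected to raise the number, by a step somewhat larger than that one. The expected change is a 6.9-fold higher number from compound 2 to compound 3 (0.84 log units; beyond the scatter). For compound 3 the estimated value is 200 nM, with an expected range from 50 nM to 800 nM.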

Compound 3, half-maximal inhibitory concentration: 529 nM
Beside the measured number, compound 3's estimate is 2.6-fold (0.42 log units) below it; the measured number falls inside the stated range.
By their numbers in this assay, from the lowest: compound 2; then compound 1; then compound 3.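

In this assay the nitro group is the weakest of the three groups tried on this aromatic carbon, ortho to a methoxy group: the change from hydroxy gives an 18-fold higher number from compound 2 to compound 3 (1.26 log units; beyond the scatter) and is large, while the change from amino gives a 5.2-fold higher number from compound 1 to compound 3 (0.72 log units; beyond the scatter) and is modest. The earlier pair showed only that hydroxy holds a lower number than amino, whereas the three compounds together give an order at this one carbon, from hydroxy through amino to nitro, and show that the position responds strongly to the group placed on it. No measurement here speaks to what lies behind this order, and the counts of donors and acceptors that change with the swap remain only a description of the two groups, with no cause to be drawn from them.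

The compounds shown leave open how a fluorine atom, a carboxylic acid or a plain hydrogen would fare on this carbon, and so whether hydroxy is the best group here or only the best of these three. They also leave open whether the same order of hydroxy, amino and nitro would hold on a different core or in other cells.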